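A few compounds are considered here, and "the series" means these few. Any claim that something is new, unique, unknown or untested is made for them only; others in the source may bear on it.

Compound 3 `CSC(=S)N1CCN(C(=S)SC(=S)N(C)C)CC1` sits at the edge of what an ADME assay on HeLa cells (Homo sapiens) for cytotoxicity, read by MTT assay, with a stated time of 24 h (on this read-out lower numbers stand for stronger inhibition and higher numbers for weaker inhibition), can report: in this assay compound 3 gives only a limit of > 5000000 nM, at the limit of > 5000000 nM in this assay, at which 1 of the 3 values shown sits. Compound 1 `CCOC(=O)N1CCN(C(=S)SC(=S)N(C)C)CC1` gives 530000 nM, and compound 2 `CN(C)C(=S)SC(=S)N1CCN(c2ccccc2)CC1` gives 1610000 nM. Compound 4 `CCCCNC(=S)N1CCN(C(=S)SC(=S)N(C)C)CC1` differs from compound 3 by butylamino in place of methylsulfanyl on a thiocarbonyl carbon. The measured steps that bear on it changed the whole group on the ring nitrogen: an at least 9.4-fold higher number from compound 1 to compound 3 (0.97 log units; beyond the scatter) and an at least 3.1-fold higher number from compound 2 to compound 3 (0.49 log units; beyond the scatter), both running up to the limit. Since the present change alters only part of that group, compound 4 is expected to stay near the limit, with a possible drop, estimated as an at least 1.6-fold lower number from compound 3 to compound 4 (0.22 log units; that floor lies within the scatter). Compound 4 is therefore expected at about 3000000 nM, between 800000 nM and 8000000 nM.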

Compound 4, half-maximal inhibitory concentration: 2840000 nM
Estimate against measurement, compound 4: 1.1-fold (0.02 log units) above; low and high end bracket the measured number.
By their numbers in this assay, from the lowest: compound 1; then compounds 2 and 4 (each within the scatter of the next). At a limit, above all of these: compound 3.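

Compound 3 gives only a limit in this assay: the limit of > 5000000 nM in this assay, at which 1 of the 4 values shown sits. Compound 4 turns that limit into a measured number, and butylamino in place of methylsulfanyl on a thiocarbonyl carbon gives an at least 1.7-fold lower number from compound 3 to compound 4 (0.24 log units; that floor lies within the scatter), a floor rather than a true size. Changing the whole group on the ring nitrogen gives a 1.8-fold higher number from compound 2 to compound 4 (0.25 log units; within the scatter) and a 5.4-fold higher number from compound 1 to compound 4 (0.73 log units; beyond the scatter), so compound 1 still has the lowest number.

On these data alone, whether a shorter chain such as ethylamino, or a longer chain such as octylamino, would shift the number remains open.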